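Swapping the carbamate of compound 2 for a thiocarbamate

The source may report more compounds than this note shows. Statements on the series, on what has been measured and on what is new or still open speak of the compounds shown alone.

Three ribose carbamates carrying the same oxolanyl-amino purine core have been measured in an assay on DDT1 cells (Cricetulus griseus) for binding affinity to adenosine receptor A1 (Homo sapiens), read by radioligand binding; a higher number here means a weaker inhibitor, a lower number a stronger inhibitor. Compound 1 `CNC(=O)OC[C@H]1OC(n2cnc3c(NC4CCOC4)nc(Cl)nc32)[C@H](O)[C@@H]1O` gives 96 nM. Compound 3 `O=C(NC1CCCC1)OC[C@H]1OC(n2cnc3c(NC4CCOC4)nc(Cl)nc32)[C@H](O)[C@@H]1O`, which differs from it only by a cyclopentyl in place of methyl on an amide-type nitrogen, gives 226 nM; the step of a 2.4-fold higher number from compound 1 to compound 3 (0.37 log units; beyond the scatter) shows the larger ring weakening binding modestly. Compound 2 `O=C(NC1CCC1)OC[C@H]1OC(n2cnc3c(NC4CCOC4)ncnc32)[C@H](O)[C@@H]1O`, which lacks the chlorine of the other two and carries a cyclobutyl on that nitrogen, gives 306 nM; this is the highest of the three numbers, within the scatter of compound 3 but beyond it relative to compound 1.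

Compound 4 `CN(C)C(=S)OC[C@H]1OC(n2cnc3c(NC4CCOC4)ncnc32)[C@H](O)[C@@H]1O` has not yet been measured. Relative to compound 2 it differs in one place: a group of 5 heavy atoms (3 carbon, 1 nitrogen, 1 sulfur; no ring) in place of a group of 7 heavy atoms (5 carbon, 1 nitrogen, 1 oxygen; one four-membered non-aromatic ring of carbon only), on an oxygen on a saturated carbon. Among the measured compounds shown here, no measured step covers this exact change. For the measured compounds named here, the only step that bears on it, from compound 1 to compound 3, concerns the size of the group on the carbamate nitrogen, and there a smaller group gave the lower number. Compound 4 carries a smaller group and loses the hydrogen-bond donor, and the effect of the sulfur for oxygen swap is not shown by any pair here. Compound 4 is therefore expected to give a number near compound 2, perhaps a little lower, with the step of a 1.5-fold lower number from compound 2 to compound 4 (0.18 log units; within the scatter) estimated. Compound 4 is estimated at 200 nM, in the range 70 nM to 600 nM.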

Compound 4, inhibition constant: 205 nM
Compound 4: middle estimate off by 1.0-fold (0.01 log units), on the low side; low and high end bracket the measured number.
By their numbers in this assay, from the lowest: compound 1; then compounds 4, 3 and 2 (each within the scatter of the next).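

In this assay, the exchange of cyclobutylcarbamoyl for the group of 5 heavy atoms with its sulfur, on an oxygen on a saturated carbon, comes to a 1.5-fold lower number from compound 2 to compound 4 (0.17 log units; within the scatter), so this single change, which removes the four-membered ring and the hydrogen-bond donor and brings in sulfur, leaves the number within the scatter. Among the compounds shown here, until now the only step at this position, a 2.4-fold higher number from compound 1 to compound 3 (0.37 log units; beyond the scatter), had changed just the group on the nitrogen, on the chlorine-bearing core, and it lay beyond the scatter; the new step shows that a far wider change of the whole group, on the core without chlorine, need not move the number beyond the scatter. Nothing shown explains this result, and no supporting measurement bears on it.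

The three changes arrive together, so the compounds shown cannot say whether each is without effect or whether their effects offset one another. As far as these compounds go, a dimethylcarbamoyl group, with a carbonyl in place of the sulfur, or a cyclobutyl group on the sulfur-bearing thiocarbamoyl would separate them, and the same sulfur-bearing group on the chlorine-bearing core remains unknown as well.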